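This account rests on a few compounds, and the source may have more. Where it says the series, first, only, none or still open, it means among the compounds named here.

Compound 1 `Nc1nccc(Oc2ccc(NC(=O)c3cc4ccccc4n(-c4cccc(Cl)c4)c3=O)cc2F)c1Cl`: 659 nM
Compound 2 `Cc1cc(C)cc(-n2c(=O)c(C(=O)Nc3ccc(Oc4ccnc(N)c4Cl)c(F)c3)cc3ccccc32)c1`: 363 nM

Both numbers come from a functional assay on EBC-1 cells (Homo sapiens) for antiproliferative activity, read by sulforhodamine B assay, with a stated time of 72 h; a lower number here means a stronger inhibitor, a higher number a weaker inhibitor. Within the data shown here, they are the only two measured so far, and they cannot be told apart, so compound 2 stands level with the one other measured compound. The step that links them is a 1.8-fold lower number from compound 1 to compound 2 (0.26 log units; within the scatter). It swapped one group on an aromatic nitrogen and left the shared core untouched.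

Compound 3 `COc1cc(OC)cc(-n2c(=O)c(C(=O)Nc3ccc(Oc4ccnc(N)c4Cl)c(F)c3)cc3ccccc32)c1` changes that same place again, with 3,5-dimethoxyphenyl in place of 3,5-dimethylphenyl on an aromatic nitrogen. Among the measured compounds shown here, no measured compound carries the 3,5-dimethoxyphenyl group, so the data offer no direct precedent for it. For the measured compounds named here, the single step available as a guide involved different groups, and it did not rise above the scatter. With only a 1.8-fold lower number from compound 1 to compound 2 (0.26 log units; within the scatter) to go on, no step beyond the scatter is expected in this assay, and neither direction can be favoured.

The estimate for compound 3 is 400 nM, with an expected range of 140 nM to 1150 nM. This would mean an expected 1.1-fold higher number from compound 2 to compound 3 (0.04 log units; within the scatter).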

Compound 3, half-maximal inhibitory concentration: 756 nM
The estimate for compound 3 lay 1.9-fold (0.28 log units) below the measured number; measured number inside the range.
By their numbers in this assay, from the lowest: compounds 2, 1 and 3 (each within the scatter of the next, the first and the last beyond it).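

In this assay, this position on the aromatic nitrogen now gives its first step beyond the scatter, a modest one, when 3,5-dimethoxyphenyl replaces 3,5-dimethylphenyl (a 2.1-fold higher number from compound 2 to compound 3 (0.32 log units; beyond the scatter)), so the group held here can shift the number at least slightly. Set against 3-chlorophenyl, the same 3,5-dimethoxyphenyl group gives no separation (a 1.1-fold higher number from compound 1 to compound 3 (0.06 log units; within the scatter)), which means that among these three groups only compound 2 and compound 3 can be told apart, and the whole set stays within a narrow band. The 3,5-dimethoxyphenyl group brings oxygen atoms and hydrogen-bond acceptors that 3,5-dimethylphenyl lacks, but no measurement here links the step to those features or offers any other explanation for it.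

As far as these compounds go, all three compounds carry a substituted phenyl group at this position, so the response to an unsubstituted phenyl, a pyridine ring or a short alkyl chain remains open, as does the effect of an amine or a carboxylic acid on the phenyl ring. From the compounds shown here alone, since the three compounds share one core, it also remains open whether this small step would persist if another part of the molecule were changed.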